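Replacing a ring amine with an amino acid headgroup

A few compounds are considered here, and "the series" means these few. Any claim that something is new, unique, unknown or untested is made for them only; others in the source may bear on it.

Compound 1 `CCCCCCCCCCc1ccc(-c2noc(CC3CNC3)n2)cc1` carries a decyl chain, an aromatic ring and a four-membered ring amine on the shared core. In an assay on HeLa cells for inhibition of sphingosine-1-phosphate transporter SPNS2 (Mus musculus), read by LC-MS, tested at 2 uM (a lower number here means less inhibition, a higher number more inhibition at the concentration tested (going by the name of the read-out)), compound 1 gives 63%, the highest of the three measured numbers. Compound 2 `CCCCCCCCCCc1ccc(-c2noc([C@@H]3CCNC3)n2)cc1` gives 62%, and the change a number 1 percentage points lower from compound 1 to compound 2 (within the scatter) stays within the scatter. Compound 3 `CCCCCCCCCCc1ccc(-c2noc(CN3CCNCC3)n2)cc1` gives 19%; here the change a number 44 percentage points lower from compound 1 to compound 3 (beyond the scatter) is large. Compound 4 `CCCCCCCCCCc1ccc(-c2noc(CC[C@@H](N)C(=O)O)n2)cc1` is not yet measured. Its difference from compound 1 is 2-amino-2-carboxyethyl in place of azetidin-3-yl on a saturated chain carbon bound to an aromatic carbon. Among the compounds with values here, two measured steps bear on this. The step from compound 1 to compound 2 shows that moving between small ring amines changes little, while the step from compound 1 to compound 3 shows that a different amine at this place can cost much inhibition. The entering group is no ring amine at all, so a drop is expected, though its size is uncertain. For compound 4 the expected change is a number 18 percentage points lower from compound 1 to compound 4 (beyond the scatter). The estimate for compound 4 is 45%, with a range from 15% to 75%.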

Compound 4, a percentage reported as inhibition, at one concentration (the size of the read-out at that concentration, not a potency): 5%
Beside the measured number, compound 4's estimate is 40 percentage points above it, and the stated range ends above it.
By their numbers in this assay, from the lowest: compound 4; then compound 3; then compounds 2 and 1 (each within the scatter of the next).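

In this assay, the change to the amino acid headgroup is far larger than the swap between the two small ring amines: the number falls by a number 58 percentage points lower from compound 1 to compound 4 (beyond the scatter) and likewise by a number 57 percentage points lower from compound 2 to compound 4 (beyond the scatter) for the same headgroup against the pyrrolidine. The piperazine in compound 3 did not mark the lowest level for this position, as the headgroup goes further still, with a number 14 percentage points lower from compound 3 to compound 4 (beyond the scatter) in a modest step. Keeping an amine is therefore not enough at this place: compound 4 still carries one, now on an open chain with a carboxylic acid.

Going by these compounds, whether the carboxylic acid or the loss of the ring matters more stays open, and a 3-aminopropyl group, with an amine on an open chain and no carboxylic acid, would separate the two. No measurement shown gives a reason for this drop.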